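A few compounds are considered here, and "the series" means these few. Any claim that something is new, unique, unknown or untested is made for them only; others in the source may bear on it.

Of the compounds shown here, three sharing one core have been tested for toxicity toward mouse fibroblast cells in an ADME assay on L929 cells (Mus musculus) for cytotoxicity, read by resazurin assay, with a stated time of 72 h; on this read-out higher numbers stand for weaker inhibition and lower numbers for stronger inhibition. In this assay compound 1, `COc1ccc(Sc2cn(-c3ccc4c(c3)B(O)OC4)c3ccccc23)cc1`, reaches only the limit > 10 ug/mL, which is a boundary of the test and not a number. Compound 2, `COc1ccc(S(=O)(=O)c2cn(-c3ccc4c(c3)B(O)OC4)c3ccccc23)cc1`, also stops at the limit > 10 ug/mL. Compound 3, `Cc1cccc(C(=O)c2ccn(-c3ccc4c(c3)B(O)OC4)c2)c1`, likewise gives only the limit > 10 ug/mL, so its place among these results is at the limit of > 10 ug/mL in this assay, at which 3 of the 3 values shown sit, together with the others. Compound 4, `NCCCC(=O)c1ccn(-c2ccc3c(c2)B(O)OC3)c1`, differs from compound 3 by 3-aminopropyl in place of 3-methylphenyl on a carbonyl carbon. Going by the values given here, no measured step sits in the data, so the expectation is a step from compound 3 to compound 4 of a step that the limit leaves unreadable from compound 3 to compound 4, none beyond the scatter. Compound 4 is therefore estimated at 15 ug/mL, within 7 ug/mL to 40 ug/mL.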

Compound 4, half-maximal inhibitory concentration: > 10 ug/mL
Compound 4: a limit, no number; the forecaster's own chance of this, stated with the estimate: 75%; the middle value is on the limit's open side.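

Going by these compounds alone, compound 3 and compound 4 each stop at a limit of the test and not at a number, so no step between them can be read: the limit of > 10 ug/mL in this assay, at which 4 of the 4 values shown sit. The compounds shown leave open at what concentration any of them would start to harm these cells.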